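This account rests on a few compounds, and the source may have more. Where it says the series, first, only, none or still open, it means among the compounds named here.

The study tracks cytotoxicity in an ADME assay on BJ cells (Homo sapiens) for cytotoxicity, with a stated time of 72 h; a lower number here means that less compound is needed, a higher number that more compound is needed for the effect. Three compounds share one core joined through a urea to a second aromatic ring. Compound 1 `Cc1cc(NC(=O)Nc2cc(F)ccc2F)c2ccccc2n1` gives 7000 nM in this assay. Compound 2 `Cc1cc(NC(=O)Nc2ncccc2C)c2ccccc2n1` gives > 25000 nM here, which is a limit of the assay and not a number (the limit of > 25000 nM in this assay, at which 1 of the 3 values shown sits). Compound 3 `Cc1cc(NC(=O)Nc2cccc(OC(F)(F)F)c2)c2ccccc2n1` gives 25000 nM in this assay, the highest of the two numbers reported, with compound 1 the nearest and lower.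

Not yet measured is compound 4 `Cc1cc(NC(=O)Nc2cccc(F)c2)c2ccccc2n1`. Compared with compound 3 it differs in one place: fluoro in place of trifluoromethoxy on an aromatic carbon. The trifluoromethoxy leaves and a fluoro enters, on an aromatic carbon of a six-membered aromatic ring of carbon only, meta to a large group. No pair of measured compounds differs in only this way, so the size of this step is not fixed by the data shown. Compound 1, which carries fluoro groups and no trifluoromethoxy, gives the lower number, 7000 nM, but it differs from compound 3 in more than one place. The step from compound 3 to compound 4 is expected to be modest, toward a lower number, a 1.7-fold lower number from compound 3 to compound 4 (0.22 log units; within the scatter), and may not exceed the scatter. Compound 4 is therefore estimated at about 15000 nM, between 6000 nM and 30000 nM.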

Compound 4, half-maximal effective concentration: > 25000 nM
Compound 4: only a limit was reported (the forecaster's own chance of this, stated with the estimate: 30%); at least 1.6-fold (0.22 log units) between middle value and limit.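

At this place, on an aromatic carbon of a six-membered aromatic ring of carbon only, meta to a large group, fluoro in place of trifluoromethoxy gives a number no lower from compound 3 to compound 4 (the limit leaves the size open) in this assay, so losing the trifluoromethoxy does not bring the number down. Compound 1 and compound 4 are listed as differing in one place, hydrogen in place of fluoro on an aromatic carbon, and that step is an at least 3.5-fold higher number from compound 1 to compound 4 (0.55 log units; beyond the scatter), so a fluoro on the ring does not by itself give the lower number of compound 1. The step between compound 2 and compound 4 cannot be read, as both values are limits of the assay and not numbers: the limit of > 25000 nM in this assay, at which 2 of the 4 values shown sit.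

Going by these compounds, how far compound 4 lies past its limit stays open, and with it the true size of the change at this position. Also open, on these data alone, is whether an amine, a carboxylic acid or a longer chain on this aromatic carbon would bring the number in this assay back within the range of the assay.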